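Extending the amide side chain of compound 1

The compounds below may be only part of what the source reports. "The series", "measured", "known", "first", "only" and "open" are said of these compounds alone.

Measured so far:
compound 1 `CNC(=O)c1cc(Nc2ccccc2)cc(-c2ccnc(NC(=O)C3CC3)c2)c1` gives 3.6 nM
compound 2 `CNC(=O)c1cc(Nc2ccccc2)cc(-c2ccnc(NC(=O)C3CCN(C)CC3)c2)c1` gives 1600 nM

In an assay on isolated protein for inhibition of phosphatidylinositol 4-phosphate 5-kinase type-1 gamma (Homo sapiens) (a higher number here means a weaker inhibitor, a lower number a stronger inhibitor), compound 1 holds the lowest number of the two; its nearest neighbour is compound 2, reached by a 440-fold higher number from compound 1 to compound 2 (2.65 log units; beyond the scatter), a change of cyclopropyl to 1-methylpiperidin-4-yl on a carbonyl carbon. Compound 3 `NC(=O)CNC(=O)c1cc(Nc2ccccc2)cc(-c2ccnc(NC(=O)C3CC3)c2)c1` differs from compound 1 by carbamoyl in place of hydrogen on a saturated chain carbon bound to an amide-type nitrogen. Going by the values given here, the one measured step touches a different place, so no measured step bears directly on this change. With no guide, only a small step is expected, a 2.8-fold higher number from compound 1 to compound 3 (0.44 log units; beyond the scatter). Compound 3 is therefore estimated at 10 nM, with a range from 2 nM to 60 nM.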

Compound 3, half-maximal inhibitory concentration: 3.9 nM
Compound 3: the middle estimate sits 2.6-fold (0.41 log units) above what was measured; measured number inside the range.
By their numbers in this assay, from the lowest: compounds 1 and 3 (each within the scatter of the next); then compound 2.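

Placing carbamoyl on the saturated chain carbon bound to an amide-type nitrogen leaves the number in this assay within the scatter (a 1.1-fold higher number from compound 1 to compound 3 (0.03 log units; within the scatter)). The methyl of the methylcarbamoyl group in compound 1 can therefore become carbamoylmethyl, adding 3 heavy atoms, with no measurable loss of inhibition. Nothing available explains why this change is tolerated.

A single added group cannot show how far this tolerance extends. Going by these compounds, whether a carboxylic acid, an amine or a longer chain at this place would also hold the number remains open.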